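Heptyl in place of 4-nitrophenyl: what to expect

This account rests on a few compounds, and the source may have more. Where it says the series, first, only, none or still open, it means among the compounds named here.

In a functional assay on HeLa cells (Homo sapiens) for inhibition, read by MTT assay, with a stated time of 48 h (a lower number here means a stronger inhibitor, a higher number a weaker inhibitor), compound 1 (`N#Cc1ccc2[nH]cc(C(c3ccc(Br)cc3)c3c[nH]c4ccc(C#N)cc34)c2c1`) gives > 100000 nM as its result, which is a limit of the assay and not a number. Compound 2 (`N#Cc1ccc2[nH]cc(C(c3ccc([N+](=O)[O-])cc3)c3c[nH]c4ccc(C#N)cc34)c2c1`) gives > 100000 nM as its result, and this too is a limit and not a number. Compound 2 therefore has no exact position on the scale. Compound 3 (`CCCCCCCC(c1c[nH]c2ccc(C#N)cc12)c1c[nH]c2ccc(C#N)cc12`) has heptyl in place of 4-nitrophenyl on a saturated chain carbon bound to two aromatic carbons. Going by the values given here, the only measured step is a step that the two limits leave unreadable from compound 1 to compound 2 and it offers no size to carry over to this change, which also replaces a ring with an open chain. Among the compounds with values here, the sole guide is the limit of > 100000 nM in this assay, at which 2 of the 2 values shown sit, and it points to no clear step in this assay, so compound 3 is expected to remain a weak inhibitor and may also be reported only as a limit. The expected step is a number no higher from compound 2 to compound 3 (the limit leaves the size open) and it is only a rough estimate. The estimated value for compound 3 is 100000 nM with a range of 30000 nM to 300000 nM as its expected span.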

Compound 3, half-maximal inhibitory concentration: 7000 nM
Compound 3: the middle estimate sits 14-fold (1.15 log units) above what was measured, and the stated range ends above it.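

In this assay, this saturated chain carbon bound to two aromatic carbons proves to be a place where a change can move the result: heptyl in place of 4-nitrophenyl gives an at least 14-fold lower number from compound 2 to compound 3 (1.15 log units; beyond the scatter), and heptyl in place of 4-bromophenyl gives an at least 14-fold lower number from compound 1 to compound 3 (1.15 log units; beyond the scatter). Going by these compounds alone, the earlier step, nitro in place of bromo, cannot be read, so the two aromatic compounds alone gave no sign that this place could shift the number at all: the limit of > 100000 nM in this assay, at which 2 of the 3 values shown sit. With heptyl, compound 3 gives 7000 nM, the only true number among the three compounds, so an open chain on this carbon is compatible with a measurable inhibition of the cells, although the true size of both steps stays unknown.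

The compounds shown leave open whether the gain comes from losing the aromatic ring or from the chain itself, a question that a cyclohexyl ring on the same carbon would address. They also leave open how the number depends on chain length, which a shorter butyl chain, a longer decyl chain or a heptyl chain ending in an amine would help to show.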